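A Furan Swap on a Weakly Cytotoxic Amide

A few compounds are considered here, and "the series" means these few. Any claim that something is new, unique, unknown or untested is made for them only; others in the source may bear on it.

Going by the values given here, in an ADME assay on SH-SY5Y cells (Homo sapiens) for cytotoxicity, read by sulforhodamine B assay, with a stated time of 72 h (on this read-out lower numbers stand for stronger inhibition and higher numbers for weaker inhibition), compound 1 `O=C(Nc1nccs1)C1CCN(Cc2ccccc2)CC1` gives 76600 nM, the only true number so far, and a high one that points to weak inhibition. Compound 2 `Cc1c(NC(=O)C2CCN(Cc3ccccc3)CC2)c(=O)n(-c2ccccc2)n1C` reads > 100000 nM, which is a limit of the assay and not a number. Compound 3 `O=C(NCc1ccco1)C1CCN(Cc2ccccc2)CC1` keeps the core of compound 1 and changes one group: (furan-2-yl)methyl in place of 1,3-thiazol-2-yl on an amide-type nitrogen. Put simply, (furan-2-yl)methyl takes the place of 1,3-thiazol-2-yl on an amide-type nitrogen. With 76600 nM for compound 1 as the only anchor, no step beyond the scatter is expected in this assay, and no direction can be called with confidence. The expected size is a 1.2-fold higher number from compound 1 to compound 3 (0.07 log units; within the scatter), which stays within the usual scatter. The estimate for compound 3 is 90000 nM, with an expected range of 45000 nM to 170000 nM.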

Compound 3, half-maximal inhibitory concentration: > 100000 nM
Compound 3: a limit, no number; the forecaster's own chance of this, stated with the estimate: 40%; middle value at least 1.1-fold (0.04 log units) from the limit.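

In this assay compound 3 gives > 100000 nM, which is a limit of the assay and not a number. With (furan-2-yl)methyl in place of 1,3-thiazol-2-yl on the amide-type nitrogen, the change can be read only as a floor, an at least 1.3-fold higher number from compound 1 to compound 3 (0.11 log units; that floor lies within the scatter), so this swap brings no stronger inhibition, though the floor alone does not show a real loss. The true size of the step cannot be given because the value of compound 3 is one of several that stop at the same limit: the limit of > 100000 nM in this assay, at which 2 of the 3 values shown sit.

Going by these compounds, how far the number for compound 3 lies past that limit remains open. Also open, on these data alone, is whether an amine or a carboxylic acid at the end of a longer chain on this nitrogen would give a true number rather than another limit.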